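A few compounds are considered here, and "the series" means these few. Any claim that something is new, unique, unknown or untested is made for them only; others in the source may bear on it.

Compound 2 `CCC(C)NC(=C\C(=O)/C=C/c1ccc(O)c(OC)c1)/C=C/c1ccc(O)c(OC)c1`: 184%
Compound 1 `CCCNC(=C\C(=O)/C=C/c1ccc(O)c(OC)c1)/C=C/c1ccc(O)c(OC)c1`: 141%

In a functional assay on EA.hy 926 cells (Homo sapiens), read by fluorescence, tested at 10 uM (on this read-out lower numbers stand for a weaker effect and higher numbers for a stronger effect at the one concentration tested), compound 2 gives 184%, the higher of the two numbers measured, while compound 1 gives 141%. Compound 3 `C=CCNC(=C\C(=O)/C=C/c1ccc(O)c(OC)c1)/C=C/c1ccc(O)c(OC)c1` has not yet been measured; it differs from compound 2 by allyl in place of sec-butyl on an amine nitrogen. For the measured compounds named here, the only measured step, a number 43 percentage points higher from compound 1 to compound 2 (beyond the scatter), concerns a different change on the same amine side chain, so no step maps directly onto this exchange. Because compound 1, which bears a propyl on that nitrogen, gives 141%, a move back toward it is expected, a step of a number 34 percentage points lower from compound 2 to compound 3 (beyond the scatter). Compound 3 is therefore estimated at 150%, with a likely range from 115% to 190%.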

Compound 3, a percentage reported as activity, at one concentration (the size of the read-out at that concentration, not a potency): 267%
Compound 3: middle estimate off by 117 percentage points, on the low side; measured number above the stated range.
By their numbers in this assay, from the lowest: compound 1; then compound 2; then compound 3.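

Putting allyl in place of sec-butyl on the amine nitrogen gives a number 83 percentage points higher from compound 2 to compound 3 (beyond the scatter) in this assay, so a branched saturated chain is not the best group at this position among these compounds. Vinyl in place of ethyl on the chain gives a number 126 percentage points higher from compound 1 to compound 3 (beyond the scatter), which ties a large rise to a double bond outside aromatic rings in this one pair. No measurement here explains why the number rises. As far as these compounds go, whether a double bond is what matters remains open: a propargyl group or a longer chain ending in a double bond on the same nitrogen could test this.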